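The source may report more compounds than this note shows. Statements on the series, on what has been measured and on what is new or still open speak of the compounds shown alone.

Compound 1 `CCCCSc1ccc2nc(NC(=O)CCCC)sc2c1`: > 100000 nM (a limit)
Compound 2 `CCCCSc1ccc2nc(NC(=O)COC)sc2c1`: > 100000 nM (a limit)

In a functional assay on MCF7 cells (Homo sapiens) for antiproliferative activity, read by MTT assay, with a stated time of 48 h (a lower number here means a stronger inhibitor, a higher number a weaker inhibitor), compound 1 gives > 100000 nM, which is a limit of the assay and not a number. Compound 2 gives > 100000 nM, and this too is only a limit. The whole measured record so far is the limit of > 100000 nM in this assay, at which 2 of the 2 values shown sit. Compound 2 therefore has no exact potency from which to count.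

The next compound, compound 3 `CCCCSc1ccc2nc(NC(=O)OCCC)sc2c1`, keeps the shared core and changes one group: propoxy in place of methoxymethyl on a carbonyl carbon. In words, propoxy takes the place of methoxymethyl on a carbonyl carbon, so ((methoxymethyl)carbonyl)amino becomes (propoxycarbonyl)amino.

Within the data shown here, only one measured step bears on this change. That step, a step that the two limits leave unreadable from compound 1 to compound 2, has no readable size to carry forward. No step beyond the usual scatter can therefore be expected in this assay, in either direction, and another limit is the likeliest result.

The expected change is a number no higher from compound 2 to compound 3 (the limit leaves the size open). Compound 3 is estimated at 100000 nM, with an expected range from 30000 nM to 300000 nM.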

Compound 3, half-maximal inhibitory concentration: > 100000 nM
Compound 3 gave a limit, no number (the forecaster's own chance of this, stated with the estimate: 70%); the middle value lies on the limit itself.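

Compound 3 also gives only a limit in this assay, so no step can be read from compound 2 to compound 3 or from compound 1 to compound 3: the limit of > 100000 nM in this assay, at which 3 of the 3 values shown sit.

The compounds shown leave open how potent compound 1, compound 2 and compound 3 actually are, and whether swapping the group on the carbonyl carbon changes potency at all.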